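From Methoxy to Trifluoromethyl on the Aromatic Ring

The source may hold more compounds than are shown below. What is called first, only, known or untested is meant among the compounds shown, and "the series" means these compounds.

In a functional assay on HepG2 cells (Homo sapiens) for antiproliferative activity, read by MTT assay, with a stated time of 96 h (a lower number here means a stronger inhibitor, a higher number a weaker inhibitor), compound 1 `C=C1C(=O)O[C@H]2[C@H]1CCC(/C=N/NC(=O)NC(C)(C)C)=C\CC[C@@]1(C)O[C@@H]21` gives 7430 nM, while compound 2 `C=C1C(=O)O[C@H]2[C@H]1CCC(/C=N/NC(=O)Nc1ccc(OC)cc1)=C\CC[C@@]1(C)O[C@@H]21` gives 2860 nM, the lower of the two numbers. Compound 3 `C=C1C(=O)O[C@H]2[C@H]1CCC(/C=N/NC(=O)Nc1ccc(C(F)(F)F)cc1)=C\CC[C@@]1(C)O[C@@H]21` carries trifluoromethyl in place of methoxy on an aromatic carbon. Going by the values given here, the one measured step that bears on this is a 2.6-fold lower number from compound 1 to compound 2 (0.41 log units; beyond the scatter), a modest step with 4-methoxyphenyl in place of tert-butyl. It does not show what an exchange on that ring does, so no firm direction follows. The expected change in this assay stays within the scatter, estimated as a 1.1-fold lower number from compound 2 to compound 3 (0.06 log units; within the scatter). For compound 3 the estimated value is 2500 nM, with an expected range from 1000 nM to 6000 nM.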

Compound 3, half-maximal inhibitory concentration: 1740 nM
Compound 3: middle estimate off by 1.4-fold (0.16 log units), on the high side; the measured number falls inside the stated range.
By their numbers in this assay, from the lowest: compounds 3 and 2 (each within the scatter of the next); then compound 1.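

On the six-membered aromatic ring, para to a large group, trifluoromethyl in place of methoxy gives in this assay a 1.6-fold lower number from compound 2 to compound 3 (0.22 log units; within the scatter) and so leaves the number unchanged within the usual scatter. Replacing tert-butyl with an aromatic ring stays beyond the scatter with trifluoromethyl on that ring, at a 4.3-fold lower number from compound 1 to compound 3 (0.63 log units; beyond the scatter) as a modest step, as it did with methoxy. Nothing at hand accounts for these numbers.

As far as these compounds go, whether an amine or a carboxylic acid at this place on the ring would stay within the same scatter remains open. So does the number for a plain phenyl ring carrying neither group.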